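Replacing an Indole with a Dimethylphenyl on a Shared Core

The compounds below may be only part of what the source reports. "The series", "measured", "known", "first", "only" and "open" are said of these compounds alone.

Compound 3 `COc1cc(-c2ccnc3cc(-c4ccc5ccn(C)c5c4)nn23)cc(OC)c1OC` holds the lowest number among the values shown in a functional assay on HCT-116 cells (Homo sapiens) for inhibition, read by CCK-8 assay, with a stated time of 48 h (a higher number here means a weaker inhibitor, a lower number a stronger inhibitor), with 1040 nM. Compound 1 `Cn1ccc2cc(-c3cc4nccc(-c5ccc(F)cc5)n4n3)ccc21` gives 2160 nM in this assay, a gap to compound 3 that lies beyond the usual scatter. Compound 2 `COc1cc(-c2ccnc3c(-c4ccc(C)cc4)cnn23)cc(OC)c1OC` gives > 10000 nM in this assay, which is a limit of the assay and not a number; it reflects (the limit of > 10000 nM in this assay, at which 1 of the 3 values shown sits).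

Compound 4 `COc1cc(-c2ccnc3cc(-c4ccc(C)c(C)c4)nn23)cc(OC)c1OC` has not yet been measured. It differs from compound 3 in one place: 3,4-dimethylphenyl in place of 1-methyl-1H-indol-6-yl on an aromatic carbon. The group that leaves brings one hydrogen-bond acceptor in its five-membered aromatic ring; the group that enters has none. Within the data shown here, no measured pair shows what this exchange does on this core, so the expectation rests on compound 3 alone. The author expects compound 4 to give a higher number than compound 3, an expected step of a 2.9-fold higher number from compound 3 to compound 4 (0.46 log units; beyond the scatter) in this assay. Compound 4 is estimated at 3000 nM, with a likely range from 800 nM to 15000 nM.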

Compound 4, half-maximal inhibitory concentration: 261 nM
For compound 4 the middle estimate is 11-fold (1.06 log units) above the measured one; measured number outside the range, below it.
By their numbers in this assay, from the lowest: compound 4; then compound 3; then compound 1. At a limit, above all of these: compound 2.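

In this assay, among these compounds, putting 3,4-dimethylphenyl in place of 1-methyl-1H-indol-6-yl gives a 4.0-fold lower number from compound 3 to compound 4 (0.60 log units; beyond the scatter), the first step that can be read at this position, an aromatic carbon of the five-membered aromatic ring with 2 nitrogen. It shows that on the shared core the 1-methyl-1H-indol-6-yl group is not required for the lower number: the entering group has fewer heavy atoms and no hydrogen-bond acceptor, yet the number still falls. Nothing measured here bears on why the step runs in this direction.

The compounds shown leave open whether both methyl groups of the 3,4-dimethylphenyl are needed, or whether an unsubstituted phenyl would give a similar number on this core. They also leave open how an aminomethyl group or a carboxylic acid in place of one methyl group would read in this assay.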